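A few compounds are considered here, and "the series" means these few. Any claim that something is new, unique, unknown or untested is made for them only; others in the source may bear on it.

For the measured compounds named here, in an ADME assay on NIH3T3 cells (Mus musculus) for cytotoxicity, read by MTT assay, with a stated time of 24 h (a higher number here means a weaker inhibitor, a lower number a stronger inhibitor), compound 1 `O=C(CSc1nnc(-c2ccncc2)o1)N/N=C/c1ccccc1` gives 167000 nM, the second highest of the three numbers so far. Compound 2 `COc1ccc(/C=N/NC(=O)CSc2nnc(-c3ccncc3)o2)cc1` gives 132000 nM and compound 3 `COc1cccc(/C=N/NC(=O)CSc2nnc(-c3ccncc3)o2)c1` gives 179000 nM; the steps of a 1.3-fold lower number from compound 1 to compound 2 (0.10 log units; within the scatter) and a 1.1-fold higher number from compound 1 to compound 3 (0.03 log units; within the scatter) stay within the scatter, as does a 1.4-fold higher number from compound 2 to compound 3 (0.13 log units; within the scatter). Compound 4 `O=C(CSc1nnc(-c2ccncc2)o1)N/N=C/c1cc(Cl)ccc1O` differs from compound 1 in one place: 5-chloro-2-hydroxyphenyl in place of phenyl on a carbon with a double bond to nitrogen. Going by the values given here, the only measured steps touching this part of the shared core are the two methoxy substitutions on the phenyl of compound 1, and neither moved the number beyond the scatter. Among the compounds with values here, no measured step covers a hydroxy or chloro on this ring, so the expectation rests on that weak precedent: no step beyond the scatter in this assay, a 1.1-fold lower number from compound 1 to compound 4 (0.05 log units; within the scatter). Compound 4 is therefore estimated at 150000 nM, in the range 80000 nM to 280000 nM.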

Compound 4, half-maximal inhibitory concentration: 166000 nM
The estimate for compound 4 lay 1.1-fold (0.04 log units) below the measured number, within the range that was stated.
By their numbers in this assay, from the lowest: compounds 2, 4, 1 and 3 (each within the scatter of the next).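

In this assay, for the compounds shown here, 5-chloro-2-hydroxyphenyl in place of phenyl adds a hydrogen-bond donor and two ring substituents at once, yet the step is a 1.0-fold lower number from compound 1 to compound 4 (0.00 log units; within the scatter), the first change at this carbon with more than a methoxy. The comparisons with the methoxy compounds also stay within the scatter: a 1.1-fold lower number from compound 3 to compound 4 (0.03 log units; within the scatter) and a 1.3-fold higher number from compound 2 to compound 4 (0.10 log units; within the scatter). No evidence is available that bears on this result. As far as these compounds go, the separate contributions of the chloro and the hydroxy remain open. Also open, from the compounds shown here alone, is whether an amine or a carboxylic acid on this ring would move the number beyond the scatter.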